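The compounds below may be only part of what the source reports. "The series", "measured", "known", "first", "only" and "open" are said of these compounds alone.

Compound 1, `CC(C)CCn1nc(-c2ccn(C)c2)c(O)c(C2=NS(=O)(=O)c3cc(NS(C)(=O)=O)ccc3N2)c1=O`: in an ADME assay on Huh-7 cells (Homo sapiens) for cytotoxicity, with a stated time of 72 h (a lower number here means that less compound is tolerated, a higher number that more compound is tolerated), compound 1 gives > 1000 nM, a limit of the assay rather than a number.
Compound 2, `CC(C)CCn1nc(-c2ccccc2)c(O)c(C2=NS(=O)(=O)c3cc(NS(C)(=O)=O)ccc3N2)c1=O`: compound 2 gives > 1000 nM, again a limit.
Compound 3, `CCCC(C)n1nc(-c2cccs2)c(O)c(C2=NS(=O)(=O)c3cc(NS(C)(=O)=O)ccc3N2)c1=O`: compound 3 gives > 33000 nM, also a limit.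

Compound 3 stands at the limit of > 33000 nM in this assay, at which 1 of the 3 values shown sits. Compounds 1 and 2 sit at the limit of > 1000 nM in this assay, at which 2 of the 3 values shown sit. Among the compounds with values here, the only step between measured compounds that differ in one place is a step that the two limits leave unreadable from compound 1 to compound 2, with phenyl in place of 1-methyl-1H-pyrrol-3-yl on an aromatic carbon; both of its ends are limits, so its size is not readable.

Compound 4, `CS(=O)(=O)Nc1ccc2c(c1)S(=O)(=O)N=C(c1c(O)c(-c3cccs3)nn(Cc3ccccc3)c1=O)N2`, differs from compound 3 by benzyl in place of 1-methylbutyl on an aromatic nitrogen. No measured step exchanges one group on the aromatic nitrogen for another, so none of the steps shown bears on this change, and the one step that exists gives no size at all. The expectation is therefore a step of an at least 1.1-fold lower number from compound 3 to compound 4 (0.04 log units; that floor lies within the scatter), no larger than the scatter. Compound 4 is estimated at 30000 nM, with a range from 8000 nM to 100000 nM, most likely reported again as a limit.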

Compound 4, half-maximal cytotoxic concentration: > 1000 nM
Compound 4 ended at the assay's limit; the forecaster's own chance of this, stated with the estimate: 70%; the middle value lies beyond the limit too.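

The step between compound 3 and compound 4 cannot be read: both results are limits of the assay, not numbers. Still open, from the compounds shown here alone, is the actual value of each of the four compounds in this assay, and whether benzyl in place of 1-methylbutyl changes it at all.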